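A Closer Look at One Swap on the Aryl Amine

The compounds below may be only part of what the source reports. "The series", "measured", "known", "first", "only" and "open" are said of these compounds alone.

Of the compounds shown here, two from this study have been tested in a functional assay on NCI-H1975 cells (Homo sapiens) for inhibition, read by MTT assay, with a stated time of 72 h; a higher number here means a weaker inhibitor, a lower number a stronger inhibitor. Compound 1 `O=C(CSc1nc(Nc2ccccc2)c2ccccc2n1)Nc1cccc([N+](=O)[O-])c1` gives 17900 nM there. Compound 2 `C=CC(=O)Nc1cccc(NC(=O)CSc2nc(Nc3cccc(F)c3)c3ccccc3n2)c1` gives 2030 nM in this assay, the lowest of the two numbers; the gap to compound 1 is beyond the scatter, so compound 2 is the stronger inhibitor of the pair. Going by the values given here, no single-point step joins these two structures, so their values can only be set side by side.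

The next compound, compound 3 `C=CC(=O)Nc1cccc(NC(=O)CSc2nc(Nc3ccc(CC)cc3)c3ccccc3n2)c1`, has not yet been measured in this assay. It differs from compound 2 in one place: 4-ethylphenyl in place of 3-fluorophenyl on a nitrogen on an aromatic ring. Cut one bond further out, the change reads (3-fluorophenyl)amino to (4-ethylphenyl)amino, while the rest of the shared core and the acrylamide side are kept.

Nothing measured here shows how this swap plays out. The expectation is a modest loss of potency, with a step of a 2.2-fold higher number from compound 2 to compound 3 (0.35 log units; beyond the scatter) that may still sit within the scatter. Compound 3 is therefore estimated at 4500 nM in this assay, with a range from 1500 nM to 14000 nM.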

Compound 3, half-maximal inhibitory concentration: 8270 nM
Estimate against measurement, compound 3: 1.8-fold (0.26 log units) below, and the stated range covers the measured number.
By their numbers in this assay, from the lowest: compound 2; then compound 3; then compound 1.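

Going by these compounds alone, this is the first comparison that changes only the group on the aryl amine, with the shared core and the acrylamide side kept the same. In this assay, 4-ethylphenyl in place of 3-fluorophenyl on that nitrogen gives a 4.1-fold higher number from compound 2 to compound 3 (0.61 log units; beyond the scatter) and so weakens inhibition, showing that the outcome in this assay depends on which aryl group sits here, something the earlier pair could not reveal as its members differ in more than one place. Nothing available here explains why the number rises.

The swap alters several things at once: the fluorine leaves, an ethyl group arrives, and the substituent sits at a different place on the ring, so the compounds shown leave open which of these changes accounts for the step. They also leave open how this acrylamide compound would respond to other groups on the same ring, such as a methoxy group, an amine or a carboxylic acid.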